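The compounds below may be only part of what the source reports. "The series", "measured", "known", "first", "only" and "open" are said of these compounds alone.

Measured so far in an ADME assay on microsomes from liver (Homo sapiens) for metabolic stability, with a stated time of 10 min; on this read-out higher numbers stand for a more stable compound and lower numbers for a less stable compound:
- Compound 1 `Fc1cccc(OC(F)(F)F)c1-c1ccc2[nH]c(C3=NOC4(CCCCC4)C3)nc2c1`: 100%
- Compound 2 `FC(F)(F)c1ccccc1-c1cc(Cl)c2[nH]c(C3=NOC4(CCCCC4)C3)nc2c1`: 92%
- Compound 3 `Fc1ccccc1-c1cc(C(F)(F)F)c2[nH]c(C3=NOC4(CCCCC4)C3)nc2c1`: 71%

The values of compound 1 and compound 2 lie within the usual scatter of each other, while compound 3 falls beyond the scatter below compound 2. Compound 2 therefore stands with compound 1 at the upper end of this small set.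

The unmeasured compound 4 `OCCCc1cc(-c2ccccc2C(F)(F)F)cc2nc(C3=NOC4(CCCCC4)C3)[nH]c12` keeps the 2-(trifluoromethyl)phenyl group of compound 2 and carries 3-hydroxypropyl in place of chloro on an aromatic carbon. The new group sits ortho to a fused ring and meta to the 2-(trifluoromethyl)phenyl group. Going by the values given here, no pair of measured compounds differs in one place, and none carries a chain of this kind, so the data offer no direct precedent for this exchange.

A downward step beyond the scatter is expected in this assay, though its size is uncertain. The lowest measured number, that of compound 3 at 71%, serves as a rough guide to how far a member of this set can lie from the top. The estimated change is a number 17 percentage points lower from compound 2 to compound 4 (beyond the scatter). For compound 4 the expected value is 75%, with an estimated range from 50% to 95%.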

Compound 4, percent of the compound remaining: 57%
The estimate for compound 4 lay 18 percentage points above the measured number, and the stated range covers the measured number.
By their numbers in this assay, from the lowest: compound 4; then compound 3; then compounds 2 and 1 (each within the scatter of the next).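

In this assay, placing 3-hydroxypropyl in place of chloro on the aromatic carbon ortho to a fused ring and meta to the 2-(trifluoromethyl)phenyl group gives a number 35 percentage points lower from compound 2 to compound 4 (beyond the scatter), a large step and the first in this set between compounds that differ in one place. It shows that this position is not neutral on this read-out: with the 2-(trifluoromethyl)phenyl group and the rest of the core held constant, the exchange at this one carbon is enough to move the number well beyond the usual scatter. Nothing measured here bears on why the number falls.

The compounds shown leave open whether the fall follows the terminal hydroxyl or the chain itself, a question that a plain propyl chain, a shorter 2-hydroxyethyl group or a methoxypropyl group on this carbon could help to settle. Also open, as far as these compounds go, is how an amine or a carboxylic acid at the end of such a chain, or a longer chain, would read in this assay at this position.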